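Azide to Amine: What to Expect for Compound 4

This account rests on a few compounds, and the source may have more. Where it says the series, first, only, none or still open, it means among the compounds named here.

Three compounds sharing one core were tested in a functional assay on IMR-32 cells (Homo sapiens) for cytotoxicity, read by MTT assay, with a stated time of 24 h; on this read-out higher numbers stand for weaker inhibition and lower numbers for stronger inhibition. Compound 1 `OCc1cc2ccccc2nc1-c1ccccc1O` carries a hydroxy group on a saturated chain carbon bound to an aromatic carbon; in this assay compound 1 sits at > 100000 nM, which is a limit of the assay and not a number. Compound 2 `[N-]=[N+]=NCc1cc2ccccc2nc1-c1ccccc1O` bears an azido group in that place, and in this assay compound 2 gives 24000 nM. Compound 3 `CS(=O)(=O)N(Cc1cn(Cc2cc3ccccc3nc2-c2ccccc2O)nn1)c1ccccc1I`, where the azide has been built into a larger group, gives 38000 nM in this assay, a value within the scatter of that of compound 2. Compound 2 thus holds the lowest of the two numbers shown, with one further value being a limit. Within the data shown here, the only measured step, an at least 4.1-fold lower number from compound 1 to compound 2 (0.61 log units; beyond the scatter), is counted against a limit, since compound 1 rests at the limit of > 100000 nM in this assay, at which 1 of the 3 values shown sits.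

Compound 4 `NCc1cc2ccccc2nc1-c1ccccc1O` differs from compound 2 by amino in place of azido on a saturated chain carbon bound to an aromatic carbon. The entering amino group brings back one hydrogen-bond donor, as the hydroxy group of compound 1 had, and that step from hydroxy to azido lowered the number. Reversing toward a donor-bearing group is therefore expected to raise the number, a step of a 2.5-fold higher number from compound 2 to compound 4 (0.40 log units; beyond the scatter), with a real chance that only a limit is reported. The estimate for compound 4 is 60000 nM, expected to lie between 20000 nM and 200000 nM.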

Compound 4, half-maximal inhibitory concentration: 46000 nM
Beside the measured number, compound 4's estimate is 1.3-fold (0.12 log units) above it; the range from low to high includes it.
By their numbers in this assay, from the lowest: compounds 2, 3 and 4 (each within the scatter of the next). At a limit, above all of these: compound 1.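

In this assay, amino in place of azido gives a 1.9-fold higher number from compound 2 to compound 4 (0.28 log units; within the scatter), so this change at the saturated chain carbon bound to an aromatic carbon cannot be told apart from the usual variation between repeated measurements. Amino in place of hydroxy gives an at least 2.1-fold lower number from compound 1 to compound 4 (0.33 log units; beyond the scatter), so having a hydrogen-bond donor at this place is not enough on its own to reach the top of the measurable range. That step is counted against a value that is a limit of the assay and not a number: the limit of > 100000 nM in this assay, at which 1 of the 4 values shown sits.

The compounds shown leave open how a longer chain, such as aminoethyl, a dimethylamino group or a carboxylic acid would behave at this place. They also leave open what separates hydroxy from amino here, and whether the same picture holds in other cell types.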